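Ester Extension on a Thiophene Amine Scaffold

The compounds below may be only part of what the source reports. "The series", "measured", "known", "first", "only" and "open" are said of these compounds alone.

Compound 1, with the structure `CCOC(=O)c1c(-c2ccc(C)cc2)csc1N`, was tested in an assay on isolated protein for inhibition of protein kinase C zeta type (Homo sapiens), with stated times of 1 h and 2.5 min, tested at 30 uM (on this read-out lower numbers stand for less inhibition and higher numbers for more inhibition at the one concentration tested (going by the name of the read-out)), and gave 80%. Among the three measured compounds it stands second highest: compound 2 `CCOC(=O)c1c(-c2ccc(OC)cc2)csc1N` gives 100%, a step described as a number 20 percentage points higher from compound 1 to compound 2 (beyond the scatter), while compound 3 `CCOC(=O)c1c(-c2ccc(C(F)(F)F)cc2)csc1N` gives 16%, a step described as a number 64 percentage points lower from compound 1 to compound 3 (beyond the scatter). From compound 2 to compound 3 the step is a number 84 percentage points lower from compound 2 to compound 3 (beyond the scatter).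

Compound 4 `Cc1ccc(-c2csc(N)c2C(=O)OCc2ccccc2)cc1` differs from compound 1 in one place: phenyl in place of methyl on a saturated chain carbon bound to an oxygen next to a carbonyl group. For the measured compounds named here, all three measured steps alter the substituent on the aromatic ring, and none touches the ester side of the shared core, so no measured step bears directly on this change. With nothing to point either way, the expectation is a step for compound 4 that stays close to compound 1, of size a number 8 percentage points lower from compound 1 to compound 4 (within the scatter), possibly within the scatter. The estimated value for compound 4 in this assay is 72%, with a range from 40% to 95%.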

Compound 4, a percentage reported as inhibition, at one concentration (the size of the read-out at that concentration, not a potency): 60%
For compound 4 the middle estimate is 12 percentage points above the measured one; measured number inside the range.
By their numbers in this assay, from the lowest: compound 3; then compound 4; then compound 1; then compound 2.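

For the compounds shown here, the ester side of the shared core, untouched by the earlier steps, turns out to affect the result in this assay: exchanging ethyl for benzyl gives a number 20 percentage points lower from compound 1 to compound 4 (beyond the scatter). The position therefore responds to change, yet it still accepts an added six-membered aromatic ring, since compound 4 keeps a reading of 60% rather than losing inhibition altogether. Nothing available explains why the benzyl ester reads lower than the ethyl ester.

The compounds shown cannot tell whether the aromatic ring itself matters or whether any larger ester group would do the same, a question that a propyl or butyl ester could help answer, while a carboxylic acid or an amide would test the ester linkage. As far as these compounds go, it also remains open whether this step would hold with methoxy or trifluoromethyl on the aromatic ring.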